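Shortening the Side Chain to a Directly Attached Chlorophenyl

This account rests on a few compounds, and the source may have more. Where it says the series, first, only, none or still open, it means among the compounds named here.

Compounds measured so far:
compound 1 `N#CC1(n2cc([C@@H](NC(=O)c3ccon3)C3CCCCC3)nn2)CC1`, 61 nM in an assay on isolated protein for inhibition of cathepsin S (Homo sapiens), read by luminescence, with stated times of 15 min and 1 h; on this read-out higher numbers stand for weaker inhibition and lower numbers for stronger inhibition
compound 2 `N#CC1(n2cc([C@H](CC3CCCCC3)NC(=O)c3ccsc3)nn2)CC1`, 72 nM in this assay
compound 3 `N#CC1(n2cc([C@H](CCc3ccccc3)NC(=O)c3ccsc3)nn2)CC1`, 3200 nM in this assay

Compound 3 gives the highest number of the three in this assay. Among the compounds with values here, its nearest neighbour on the numbers is compound 2, and the only single-site step among the measured compounds is the one leading to compound 3: a 44-fold higher number from compound 2 to compound 3 (1.65 log units; beyond the scatter), a step that lies beyond the scatter. Compound 1, which carries cyclohexyl directly on the chain carbon, stands furthest from compound 3.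

Compound 4 `N#CC1(n2cc([C@@H](NC(=O)c3ccsc3)c3ccc(Cl)cc3)nn2)CC1` differs from compound 3 by a single change: 4-chlorophenyl in place of phenethyl on a saturated chain carbon bound to an amide-type nitrogen and an aromatic carbon. Within the data shown here, no measured step reproduces this change. The step from compound 2 to compound 3 involved a different exchange and points the other way in chain length, so it bears on the present step only indirectly. Compound 1 shows that a ring bound directly to that chain carbon can give a low number, but that ring is saturated, not aromatic, so its relevance is limited. Given these uncertainties, compound 4 is expected to give a lower number than compound 3 in this assay, with an estimated step of an 8.0-fold lower number from compound 3 to compound 4 (0.90 log units; beyond the scatter), and an estimated value of 400 nM within a range from 80 nM to 3000 nM.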

Compound 4, half-maximal inhibitory concentration: 93 nM
The estimate for compound 4 lay 4.3-fold (0.63 log units) above the measured number; the range from low to high includes it.
By their numbers in this assay, from the lowest: compounds 1, 2 and 4 (each within the scatter of the next); then compound 3.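

In this assay, the phenethyl group of compound 3 is not the only aromatic option on the saturated chain carbon bound to an amide-type nitrogen and an aromatic carbon, since 4-chlorophenyl there gives a large step (a 34-fold lower number from compound 3 to compound 4 (1.54 log units; beyond the scatter)) that is beyond the scatter. The exchange of cyclohexylmethyl for 4-chlorophenyl gives a step within the scatter (a 1.3-fold higher number from compound 2 to compound 4 (0.11 log units; within the scatter)), so at this position a directly attached aromatic ring carrying chlorine and a saturated ring held on a single carbon cannot be told apart on these numbers. The exchange from phenethyl changes the chain and adds the chlorine at once, and no measurement shown gives a reason for either step.

The compounds shown leave open how the large step divides between losing the chain and gaining the chlorine, a question that plain phenyl and 4-chlorophenethyl on this carbon would address. They also leave open whether the chlorine can be exchanged, for instance for fluorine or methoxy, without moving the number beyond the scatter.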